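This account rests on a few compounds, and the source may have more. Where it says the series, first, only, none or still open, it means among the compounds named here.

Working notes on the series. The three measured compounds share one core and differ only in the chain on the nitrogen on the aromatic ring. Compound 1 `CNCCNc1cc(N2CCCc3ccc(F)cc3C2)nc2ccc(C)cc12` gives 29000 nM in an ADME assay on HEp-2 cells (Homo sapiens) for cytotoxicity, read by CCK-8 assay, with a stated time of 5 days; a lower number here means that less compound is tolerated, a higher number that more compound is tolerated. Compound 2 `Cc1ccc2nc(N3CCCc4ccc(F)cc4C3)cc(NC(C)CN)c2c1` gives 25000 nM in this assay, and compound 3 `Cc1ccc2nc(N3CCCc4ccc(F)cc4C3)cc(NCC(C)N)c2c1` gives 86000 nM in this assay. Compound 3 therefore holds the highest number of the three: the step of a 3.0-fold higher number from compound 1 to compound 3 (0.47 log units; beyond the scatter) and the step of a 3.4-fold higher number from compound 2 to compound 3 (0.54 log units; beyond the scatter) both lie beyond the scatter, while the step of a 1.2-fold lower number from compound 1 to compound 2 (0.06 log units; within the scatter) does not.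

Compound 4 `Cc1ccc2nc(N3CCCc4ccc(F)cc4C3)cc(NCCN3CCCCC3)c2c1` is not yet measured in this assay. The change from compound 3 is (piperidin-1-yl)methyl in place of 1-aminoethyl on a saturated chain carbon bound to a nitrogen on an aromatic ring. Among the compounds with values here, no measured step introduces a ring at this place; the two steps that bear on it, a 3.0-fold higher number from compound 1 to compound 3 (0.47 log units; beyond the scatter) and a 3.4-fold higher number from compound 2 to compound 3 (0.54 log units; beyond the scatter), only rearranged the amine chain, and each moved the number by a modest amount. On that basis a modest step is expected from compound 3 to compound 4 in this assay, downward toward the numbers of compound 1 and compound 2, worded as a 2.2-fold lower number from compound 3 to compound 4 (0.33 log units; beyond the scatter), though a result within the scatter would not surprise. Compound 4 is accordingly estimated at 40000 nM in this assay, with a range from 13000 nM to 120000 nM.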

Compound 4, half-maximal cytotoxic concentration: 22000 nM
Estimate against measurement, compound 4: 1.8-fold (0.26 log units) above, and the stated range covers the measured number.
By their numbers in this assay, from the lowest: compounds 4, 2 and 1 (each within the scatter of the next); then compound 3.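

In this assay, within the data shown here, a ring at this place is met for the first time, and a 3.9-fold lower number from compound 3 to compound 4 (0.59 log units; beyond the scatter) shows that the high number does not survive the exchange of 1-aminoethyl for (piperidin-1-yl)methyl on a saturated chain carbon bound to a nitrogen on an aromatic ring. The ring-bearing chain nevertheless stays level with both open-chain amines, as a 1.1-fold lower number from compound 2 to compound 4 (0.06 log units; within the scatter) and a 1.3-fold lower number from compound 1 to compound 4 (0.12 log units; within the scatter) each lie within the scatter. Among these four, the count of heavy atoms in the group and the presence of a ring therefore give no guide to the number, and the 2-aminopropyl chain of compound 3 alone stands apart. No measurement at hand accounts for any of these steps.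

Still open, from the compounds shown here alone, is whether the high number of compound 3 belongs specifically to the 2-aminopropyl arrangement or would also appear with a 3-aminopropyl chain or a 2-(dimethylamino)ethyl chain. The compounds shown also leave open whether a pyrrolidine or morpholine ring in place of piperidine would stay level with compound 4 or move the number.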